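A few compounds are considered here, and "the series" means these few. Any claim that something is new, unique, unknown or untested is made for them only; others in the source may bear on it.

Measured so far:
- Compound 1 `CN(C)C1(COc2cccnc2)CC1`: 95 nM
- Compound 2 `NC1(COc2cccnc2)CC1`: 34 nM
- Compound 3 `CN(C)C1(COc2ccc(Cl)nc2)CC1`: 304 nM

In an assay on brain for displacement of a labelled ligand from Neuronal acetylcholine receptor; alpha4/beta2 (Rattus norvegicus) (on this read-out lower numbers stand for stronger inhibition and higher numbers for weaker inhibition), compound 1 gives 95 nM, the second highest of the three numbers. The nearest measured neighbour is compound 2, which shows a 2.8-fold lower number from compound 1 to compound 2 (0.45 log units; beyond the scatter) with amino in place of dimethylamino on a saturated ring carbon. The furthest is compound 3, which shows a 3.2-fold higher number from compound 1 to compound 3 (0.51 log units; beyond the scatter) with chloro in place of hydrogen on an aromatic carbon.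

Compound 4 `CN(C)C1(COc2cncc(Br)c2)CC1` has not yet been measured. It differs from compound 1 by bromo in place of hydrogen on an aromatic carbon. Within the data shown here, of the two known steps, only the one to compound 3 bears on this change, since it also places a halogen on the same aromatic ring of the shared core; that step was modest and moved toward a higher number, though the halogen and its place on the ring both differ from those in compound 4. The step to compound 2 touches a different part of the molecule and says nothing about it.

Among the measured compounds shown here, a modest rise in this assay is therefore expected, with wide uncertainty because the place of the bromo has no direct precedent. For compound 4 the expected result in this assay is 200 nM, with a range from 60 nM to 650 nM. This corresponds to an expected step of a 2.1-fold higher number from compound 1 to compound 4 (0.32 log units; beyond the scatter).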

Compound 4, inhibition constant: 273 nM
Beside the measured number, compound 4's estimate is 1.4-fold (0.14 log units) below it; measured number inside the range.
By their numbers in this assay, from the lowest: compound 2; then compound 1; then compounds 4 and 3 (each within the scatter of the next).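

Among these compounds, the new compound gives the first direct reading for this place on the ring, two atoms from the ring nitrogen and meta to a group of 8 heavy atoms. In this assay bromo in place of hydrogen here gives a 2.9-fold higher number from compound 1 to compound 4 (0.46 log units; beyond the scatter) and so this position does not accept the added atom without a loss of binding strength. Chloro at a different place on the same ring had already given a 3.2-fold higher number from compound 1 to compound 3 (0.51 log units; beyond the scatter) and the two results now point the same way, so a rise in the number is no longer tied to one halogen at one place, although these two compounds alone cannot establish a general rule for halogens on this ring.

The compounds shown leave open whether the rise belongs to bromo in particular or would follow any replacement of hydrogen here, a question that fluoro, methyl, methoxy or an amine at this same place could help to settle. From the compounds shown here alone, it also remains open whether bromo would have a similar effect with the amino group of compound 2 in place of dimethylamino. No measurement offered here explains why the number rises with bromo at this place.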